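The source may report more compounds than this note shows. Statements on the series, on what has been measured and on what is new or still open speak of the compounds shown alone.

Measured compounds:
Compound 1, `COc1ccc(-c2cc3[nH]nc(N)c3c(=O)[nH]2)cc1`, gives 43%.
Compound 2, `CN1CCN(c2ccc(-c3cc4[nH]nc(N)c4c(=O)[nH]3)cc2)CC1`, gives 68%.
Compound 3, `COc1ccc(-c2cc3nn(-c4ccccc4)c(N)c3c(=O)[nH]2)cc1`, gives -3%.

These three compounds were tested in an assay on isolated protein for inhibition of serine/threonine-protein kinase Chk2 (Homo sapiens), read by mobility shift assay, tested at 30 uM; on this read-out higher numbers stand for more inhibition at the one concentration tested (going by the name of the read-out) and lower numbers for less inhibition. Compound 1 and compound 2 share one core and differ in a single place: 4-methylpiperazin-1-yl in place of methoxy on an aromatic carbon. This change gave a step of a number 25 percentage points higher from compound 1 to compound 2 (beyond the scatter). Compound 3 carries a different core, one that bears a phenyl group on a ring nitrogen, and in this assay compound 3 sits lowest of the three; the difference between the core of compound 3 and the core of compound 1 is not broken down here.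

Compound 4, `CN1CCN(c2ccc(-c3cc4nn(-c5ccccc5)c(N)c4c(=O)[nH]3)cc2)CC1`, has not yet been measured. It is made from compound 3 by the same change already seen between compound 1 and compound 2: 4-methylpiperazin-1-yl in place of methoxy on an aromatic carbon. The place of the change is described in the same words in both pairs, so the two changes are the same.

Whether the change will repeat its earlier effect is uncertain, since the starting point is now a compound that showed essentially no inhibition. The step from compound 3 to compound 4 is expected to be a number 13 percentage points higher from compound 3 to compound 4 (beyond the scatter), somewhat smaller than the earlier step, because compound 3 gives -3% and the rise seen from compound 1 to compound 2 need not carry over onto a core whose own number in this assay is lower. For compound 4 the expected value in this assay is 10%, with a likely range from -10% to 35%.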

Compound 4, a percentage reported as inhibition, at one concentration (the size of the read-out at that concentration, not a potency): 18%
Compound 4: the middle estimate sits 8 percentage points below what was measured; measured number inside the range.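

Putting 4-methylpiperazin-1-yl in place of methoxy on the core that bears a phenyl group on a ring nitrogen gave, in this assay, a number 21 percentage points higher from compound 3 to compound 4 (beyond the scatter). Set beside the same change on the core of compound 1, the two steps agree, so in this series the change carried over from one core to the other with much the same size: the same change on two cores in this assay, a number 25 percentage points higher (beyond the scatter) from compound 1 to compound 2 and a number 21 percentage points higher (beyond the scatter) from compound 3 to compound 4, 4 percentage points apart, within the scatter of two such steps. Within the data shown here, this rests on only two pairs of compounds, each tested at a single concentration, so it does not show that the step would repeat on any further core or why the number rises, and carrying the step over did not bring the two cores level, since compound 4 gives 18% while compound 2 gives 68%.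

The compounds shown leave open whether other groups in the same place, such as a morpholine ring, a simple primary amine, a carboxylic acid or a piperazine without its methyl, would give a similar rise. They also leave open whether the step would hold with something other than phenyl on the ring nitrogen, such as a methyl or a benzyl group.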